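Two Measured Compounds and an Expectation for a Third

The compounds below may be only part of what the source reports. "The series", "measured", "known", "first", "only" and "open" are said of these compounds alone.

Of the compounds shown here, two of one series have been tested in a functional assay on COLO 205 cells (Homo sapiens) for inhibition, read by sulforhodamine B assay, with a stated time of 48 h, tested at 10 uM; on this read-out lower numbers stand for a stronger effect and higher numbers for a weaker effect at the one concentration tested. Compound 1 `COc1cc(Cl)cc(-c2nn(-c3cccc(NC(=O)Nc4ccc(Cl)c(C(F)(F)F)c4)c3)cc2-c2ccncc2)c1` gives -48.3% in this assay. Compound 2 `COc1cc(Cl)cc(-c2nn(-c3cccc(NC(=O)Nc4cccc(C(F)(F)F)c4)c3)cc2-c2ccncc2)c1` gives -31.2% in this assay. Among the measured compounds shown here, compound 2 therefore stands highest of the two numbers, which here means the weaker effect; its only neighbour is compound 1, and the single measured step, a number 17.1 percentage points higher from compound 1 to compound 2 (beyond the scatter), comes with hydrogen in place of chloro on an aromatic carbon.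

Compound 3 `COc1cc(Cl)cc(-c2nn(-c3cccc(NC(=O)c4cccc(C(F)(F)F)c4)c3)cc2-c2ccncc2)c1` has not yet been measured. It differs from compound 2 at one place: 3-(trifluoromethyl)phenyl in place of (3-(trifluoromethyl)phenyl)amino on a carbonyl carbon. The group that leaves carries one hydrogen-bond donor, the group that enters carries none, and the carbonyl carbon keeps an amide-type nitrogen as its other neighbour.

For the measured compounds named here, no measured step concerns a change of this kind; the one known step concerns a chloro at another place, so it gives no direct guide. With the loss of a hydrogen-bond donor and little else to go on, a step of a number 11.2 percentage points higher from compound 2 to compound 3 (beyond the scatter) toward a weaker effect is expected, but with wide uncertainty. Compound 3 is estimated at -20%, within a range from -50% to 10%.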

Compound 3, a percentage reported as activity, at one concentration (the size of the read-out at that concentration, not a potency): 68.5%
Compound 3: the middle estimate sits 88.5 percentage points below what was measured; measured number outside the range, above it.
By their numbers in this assay, from the lowest: compound 1; then compound 2; then compound 3.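

The change on the carbonyl carbon, 3-(trifluoromethyl)phenyl in place of (3-(trifluoromethyl)phenyl)amino, matters far more in this assay than the chloro change did: it gives a number 99.7 percentage points higher from compound 2 to compound 3 (beyond the scatter), against only a number 17.1 percentage points higher from compound 1 to compound 2 (beyond the scatter) for the loss of chloro. Replacing (4-chloro-3-(trifluoromethyl)phenyl)amino at the same place gives a number 116.8 percentage points higher from compound 1 to compound 3 (beyond the scatter), so the largest steps shown both involve this position. Compound 2 reads -31.2% and compound 3 reads 68.5%, so the read-out changes sign, and among these compounds the stronger effect goes with the amino group and its hydrogen-bond donor, with no compound going against that pairing.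

Nothing available accounts for the size of this step. On these data alone, it also remains open whether the nitrogen itself or only the hydrogen on it goes with the stronger effect, a question that compounds with a methylamino link, an oxygen or a methylene group on the carbonyl carbon in place of the amino nitrogen could help to separate.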